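Varying the group on the five-membered ring: toward compound 4

The source may hold more compounds than are shown below. What is called first, only, known or untested is meant among the compounds shown, and "the series" means these compounds.

Measured compounds and values:
compound 1, `O=C(O)CCc1ccc(-c2ccc3cnn(-c4ccccn4)c3c2)cc1`, 4500 nM
compound 2, `COc1nn(-c2ccccn2)c2cc(-c3ccc(CCC(=O)O)cc3)ccc12`, 2600 nM
compound 3, `CCc1nn(-c2ccccn2)c2cc(-c3ccc(CCC(=O)O)cc3)ccc12`, 1100 nM

All three share one core and differ only in the group on an aromatic carbon of the five-membered aromatic ring with two nitrogens. In a functional assay on cells for agonist activity at Free fatty acid receptor 1 (Mus musculus), read by FLIPR and calcium flux, with a stated time of 5 min (a higher number here means that more compound is needed for the effect, a lower number that less compound is needed), compound 3 gives the lowest of the three numbers. Its nearest neighbour is compound 2, and the step of a 2.4-fold lower number from compound 2 to compound 3 (0.37 log units; beyond the scatter) is modest but beyond the scatter. The step of a 4.1-fold lower number from compound 1 to compound 3 (0.61 log units; beyond the scatter) is larger. Between compound 1 and compound 2 the step of a 1.7-fold lower number from compound 1 to compound 2 (0.24 log units; within the scatter) lies within the scatter, so those two cannot be ordered.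

Compound 4, `N#Cc1nn(-c2ccccn2)c2cc(-c3ccc(CCC(=O)O)cc3)ccc12`, is not yet measured in this assay. It differs from compound 3 as follows: cyano in place of ethyl on an aromatic carbon. The bearing steps are those that put a group onto this carbon or exchange one group for another there: the gains from hydrogen to methoxy, from hydrogen to ethyl and from methoxy to ethyl. Ethyl gave the lowest number; methoxy gave a higher one; no group with a triple bond or an added hydrogen-bond acceptor has been tried here. The expectation is therefore a modest rise from compound 3 to compound 4, a 1.8-fold higher number from compound 3 to compound 4 (0.26 log units; within the scatter), with a wide range on either side. For compound 4 the estimated value in this assay is 2000 nM, expected between 700 nM and 6000 nM.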

Compound 4, half-maximal effective concentration in the Free fatty acid receptor 1 assay: 2000 nM
Compound 4: the middle estimate sits on the measured number at the digits printed; the range from low to high includes it.
By their numbers in the Free fatty acid receptor 1 assay, from the lowest: compounds 3, 4, 2 and 1 (each within the scatter of the next, the first and the last beyond it).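

Notes on this carbon of the five-membered ring: in the Free fatty acid receptor 1 assay, compound 4 gives 2000 nM, so a group with a triple bond and a hydrogen-bond acceptor can stand here without a step beyond the scatter from ethyl (a 1.8-fold higher number from compound 3 to compound 4 (0.26 log units; within the scatter)) or from methoxy (a 1.3-fold lower number from compound 2 to compound 4 (0.11 log units; within the scatter)), and these two steps do not separate compound 4 from compound 3 or from compound 2. Cyano, like ethyl but unlike methoxy, does clear the scatter against hydrogen, with a modest step (a 2.3-fold lower number from compound 1 to compound 4 (0.35 log units; beyond the scatter)), which makes a substituent at this carbon more than a neutral exchange in two of the three cases. In a physicochemical assay for lipophilicity, using the shake flask method, measured as octanol-water partition, with a stated time of 30 min, at pH 7.4 (a lower number here means a more polar compound, a higher number a more lipophilic compound), compound 3 gives 3.3 and compound 4 gives 3, so the exchange of ethyl for cyano also stays within the scatter (a number 0.30 log units lower from compound 3 to compound 4 (within the scatter)), and nothing shown explains either read-out.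

Open, going by these compounds, is whether any group at this carbon takes the number clearly below that of compound 3, for instance a propyl or longer chain, an amine, an amide or a carboxylic acid. Also open, on these data alone, is whether the small differences among ethyl, methoxy and cyano persist when the pyridin-2-yl group is replaced by another group.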